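The source may hold more compounds than are shown below. What is called first, only, known or untested is meant among the compounds shown, and "the series" means these compounds.

Working notes on the series. Two compounds have a number in a functional assay on the whole organism (strain albino) with Rattus norvegicus as the target, read by paw edema, with stated times of 1 h and 4 h, at a dose of 50 mg/kg by the oral route; a higher number here means a stronger effect of the compound at the dose given, a lower number a weaker effect. Compound 1 `COc1ccc(Cl)cc1C(=O)Nc1ccc(C2=NN(C)C(c3ccccc3[N+](=O)[O-])C2)cc1` gives 99.5% in this assay. Compound 2 `COc1ccc(C2CC(c3ccc(NC(=O)c4cc(Cl)ccc4OC)cc3)=NN2)cc1` gives 89% in this assay, the lowest of the two numbers recorded; its nearest neighbour is compound 1, whose number lies higher by a margin beyond the usual scatter of the read-out. Among the compounds with values here, no pair of measured compounds differs in a single place, so no measured step is available to lean on.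

Compound 3 `COc1ccc(Cl)cc1C(=O)Nc1ccc(C2=NNC(c3ccccc3[N+](=O)[O-])C2)cc1` has not yet been measured in this assay. Against compound 2 the change is 2-nitrophenyl in place of 4-methoxyphenyl on a saturated ring carbon. Within the data shown here, compound 1, the only other measured compound, also carries a 2-nitrophenyl group and gives the higher of the two numbers, but since no single-place step is recorded between it and compound 3, that is read only as the values themselves show.

With the whole series already sitting high on the percentage scale, the step from compound 2 to compound 3 is expected to be small and upward, at most around the edge of the scatter, a number 6 percentage points higher from compound 2 to compound 3 (within the scatter). For compound 3 in this assay the estimate is 95%, within a range of 85% to 100%.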

Compound 3, a percentage reported as activity, at one dose (the size of the read-out at that dose, not a potency): 90.9%
Estimate against measurement, compound 3: 4.1 percentage points above; measured number inside the range.
By their numbers in this assay, from the lowest: compounds 2, 3 and 1 (each within the scatter of the next, the first and the last beyond it).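

On the saturated ring carbon, 2-nitrophenyl in place of 4-methoxyphenyl gives a number 1.9 percentage points higher from compound 2 to compound 3 (within the scatter) in this assay, so at this dose the read-out does not separate these two groups at this position. Within the data shown here, the amine nitrogen in the ring comes into view for the first time with a single change: hydrogen in place of methyl gives a number 8.6 percentage points lower from compound 1 to compound 3 (within the scatter), and this step also does not separate its two compounds, so neither single change taken alone produces a step beyond the scatter. No independent measurement bears on these two steps.

The compounds shown leave open whether this position tolerates a phenyl ring carrying an amine or a carboxylic acid as freely as it tolerates 2-nitrophenyl and 4-methoxyphenyl. They also leave open what an ethyl group or a longer chain on the ring nitrogen would do in this assay, since only hydrogen and methyl appear there.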